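Nitro to bromo on compound 2

The source may hold more compounds than are shown below. What is called first, only, known or untested is meant among the compounds shown, and "the series" means these compounds.

In a functional assay on HCT-116 cells (Homo sapiens) for inhibition, read by MTT assay, with a stated time of 48 h (a higher number here means a weaker inhibitor, a lower number a stronger inhibitor), compound 2 (`COc1ccc(CNc2cc(OC)c(OC)c(OC)c2)cc1[N+](=O)[O-]`) gives 18200 nM, the highest number of the three measured. Compound 1 (`C/C=C/C(=O)N(Cc1ccc(OC)c([N+](=O)[O-])c1)c1cc(OC)c(OC)c(OC)c1`) gives 670 nM, and compound 3 (`COc1ccc(CN(C(=O)C(C)Br)c2cc(OC)c(OC)c(OC)c2)cc1O`) gives 140 nM. Compound 4 (`COc1ccc(CNc2cc(OC)c(OC)c(OC)c2)cc1Br`) has bromo in place of nitro on an aromatic carbon. Going by the values given here, the only measured step, a 27-fold higher number from compound 1 to compound 2 (1.43 log units; beyond the scatter), concerns the group on the nitrogen, not this carbon, so it bears only indirectly. Compound 3 differs from compound 2 in more than one place. Among the compounds with values here, no measured pair isolates this swap, so no step beyond the scatter is expected in this assay, and neither direction is favoured. The expected step is a 1.2-fold lower number from compound 2 to compound 4 (0.08 log units; within the scatter). Compound 4 is estimated at 15000 nM, with an expected range of 5000 nM to 50000 nM.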

Compound 4, half-maximal inhibitory concentration: 48100 nM
Compound 4: middle estimate off by 3.2-fold (0.51 log units), on the low side, within the range that was stated.
By their numbers in this assay, from the lowest: compound 3; then compound 1; then compound 2; then compound 4.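

In this assay, the aromatic carbon ortho to a methoxy group proves sensitive to its substituent, which the earlier step on the nitrogen could not show: bromo in place of nitro gives a 2.6-fold higher number from compound 2 to compound 4 (0.42 log units; beyond the scatter), a modest step beyond the scatter. Within this pair, nitro is the better of the two groups, though both compounds remain weak beside compound 1 and compound 3. No evidence here accounts for the rise. From the compounds shown here alone, how an amine or a nitrile on this carbon would compare stays open. Also open, going by these compounds, is whether the step carries over when the nitrogen bears a carbonyl group, as in compound 1.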